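Para substituent swap on the aryl urea: isopropyl to bromo

The source may hold more compounds than are shown below. What is called first, only, known or untested is meant among the compounds shown, and "the series" means these compounds.

Measured so far:
compound 1 `CC(C)c1ccc(NC(=O)N2CCN(c3ncccc3Cl)CC2)cc1` 17.3 nM
compound 2 `CC(C)c1ccc(NC(=O)N2CCN(c3ncccc3C(F)F)CC2)cc1` 61.5 nM

In a functional assay on HEK293 cells for antagonist activity at transient receptor potential cation channel subfamily V member 1 (Rattus norvegicus) (a higher number here means a weaker inhibitor, a lower number a stronger inhibitor), compound 1 gives the lower of the two numbers; compound 2 sits a 3.6-fold higher number from compound 1 to compound 2 (0.55 log units; beyond the scatter) away. Compound 3 `O=C(Nc1ccc(Br)cc1)N1CCN(c2ncccc2Cl)CC1` keeps the chloro-bearing core of compound 1 and changes the other end: bromo in place of isopropyl on an aromatic carbon. Going by the values given here, no measured step touches this position, so the only step known, from compound 1 to compound 2, concerns a different place and gives no direct guide. With nothing to anchor the change, a small weakening is expected for compound 3, a 2.3-fold higher number from compound 1 to compound 3 (0.36 log units; beyond the scatter), with wide uncertainty. Compound 3 is estimated at 40 nM, plausibly between 10 nM and 160 nM.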

Compound 3, half-maximal inhibitory concentration: 1010 nM
The estimate for compound 3 lay 25-fold (1.40 log units) below the measured number; the measured number lies above the stated range.
By their numbers in this assay, from the lowest: compound 1; then compound 2; then compound 3.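

In this assay, going by these compounds alone, the aromatic carbon para to a large group proves far more sensitive than the earlier compounds could show: bromo in place of isopropyl gives a 58-fold higher number from compound 1 to compound 3 (1.77 log units; beyond the scatter), a large step. The change of chloro to difluoromethyl at the other end gave only a 3.6-fold higher number from compound 1 to compound 2 (0.55 log units; beyond the scatter). Nothing available accounts for this loss.

This single pair cannot separate the loss of isopropyl from the entry of bromo. Going by these compounds, whether a tert-butyl, a trifluoromethyl or a methoxy group at this position would hold the number of compound 1 remains open.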